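The source may report more compounds than this note shows. Statements on the series, on what has been measured and on what is new or still open speak of the compounds shown alone.

Measured compounds:
compound 1, `O=C1c2sc(C#Cc3ccccc3)nc2CN1C1CC1`: 23 nM
compound 2, `CCC(=O)N1CCc2nc(C#Cc3ccccc3)sc2C1`: 38 nM

In an assay on HEK293 cells for negative allosteric modulation of metabotropic glutamate receptor 5 (Homo sapiens), read by FLIPR, with a stated time of 1 h (on this read-out lower numbers stand for stronger inhibition and higher numbers for weaker inhibition), compound 2 gives 38 nM, the highest of the two numbers shown, while compound 1 gives 23 nM, a gap that lies within the scatter. Compound 3, `CC1CCCC(C(=O)N2CCc3nc(C#Cc4ccccc4)sc3C2)C1`, differs from compound 2 in one place: 3-methylcyclohexyl in place of ethyl on a carbonyl carbon. Within the data shown here, no step between two measured compounds covers a change of this kind, so the expectation rests on compound 2 alone. Compound 3 is expected to stay close to compound 2, with a step of a 1.3-fold lower number from compound 2 to compound 3 (0.10 log units; within the scatter) that is not beyond the scatter. The estimate for compound 3 in this assay is 30 nM, with a range from 10 nM to 100 nM.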

Compound 3, half-maximal inhibitory concentration: > 10000 nM
Compound 3 gave a limit, no number (the forecaster's own chance of this, stated with the estimate: 3%); at least 330-fold (2.52 log units) between middle value and limit.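

In this assay, compound 3 gives only a limit, not a number: the limit of > 10000 nM in this assay, at which 1 of the 3 values shown sits. Among these compounds, putting 3-methylcyclohexyl in place of ethyl on a carbonyl carbon gives an at least 260-fold higher number from compound 2 to compound 3 (2.42 log units; beyond the scatter), so this place does not accept every group, which the earlier compounds could not show. Neither group carries hydrogen-bond donors, hydrogen-bond acceptors or a net charge, so the step goes with added carbon and the six-membered ring.

On these data alone, it remains open whether a propyl chain, a cyclopropyl ring or a plain cyclohexyl without the methyl would keep the inhibition seen with ethyl.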